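This account rests on a few compounds, and the source may have more. Where it says the series, first, only, none or still open, it means among the compounds named here.

Compound 1, whose structure is `O=c1[nH]cnc2c1c(-c1cccs1)cn2[C@@H]1O[C@H](CO)[C@@H](O)[C@H]1O`, is the starting point. In an ADME assay on MRC5 cells (Homo sapiens), read by MTT assay, with a stated time of 72 h (on this read-out higher numbers stand for weaker inhibition and lower numbers for stronger inhibition), compound 1 gives > 100000 nM, which is a limit of the assay rather than a measured number. Two other compounds give some sense of the surroundings. Compound 3, with the structure `Nc1nc2c(c(-c3cccs3)cn2[C@@H]2O[C@H](CO)[C@@H](O)[C@H]2O)c(=O)[nH]1`, differs from compound 1 only by carrying one added amino group. In this assay compound 3 gives > 100000 nM, again a limit of the assay. The step that the two limits leave unreadable from compound 1 to compound 3 therefore cannot be read, because both ends sit at the limit of > 100000 nM in this assay, at which 2 of the 3 values shown sit. Within the data shown here, compound 2, with the structure `Cc1ncnc2c1c(-c1cc3ccccc3o1)cn2[C@@H]1O[C@H](CO)[C@@H](O)[C@H]1O`, is the only one with a numerical value: in this assay compound 2 gives 84400 nM.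

The compound not yet measured is compound 4, with the structure `O=c1[nH]cnc2c1c(-c1ccccc1)cn2[C@@H]1O[C@H](CO)[C@@H](O)[C@H]1O`. Its difference from compound 1 is phenyl in place of thiophen-2-yl on an aromatic carbon. Among the measured compounds shown here, no measured step concerns this exchange, and the one step that exists is unreadable, so the only guide is that compound 1 itself sits at the limit. The expectation is that compound 4 stays near that same limit, with a step that the limit leaves unreadable from compound 1 to compound 4 that is not expected to exceed the usual scatter. Compound 4 is therefore estimated at 130000 nM, within a range from 50000 nM to 400000 nM.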

Compound 4, half-maximal inhibitory concentration: > 100000 nM
Compound 4 gave a limit, no number; the forecaster's own chance of this, stated with the estimate: 75%; the middle value lies beyond the limit too.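

Compound 4 gives a limit of the assay rather than a number, so the step from compound 1 to compound 4 cannot be read, because both ends sit at a limit: the limit of > 100000 nM in this assay, at which 3 of the 4 values shown sit.

The compounds shown leave open whether phenyl and thiophen-2-yl on the shared core differ at all in this assay.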